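The source may report more compounds than this note shows. Statements on the series, on what has been measured and on what is new or still open speak of the compounds shown alone.

Measured so far:
- compound 1 `C#CCN(CCCOc1ccc2ccc(=O)oc2c1)Cc1ccc(C)cc1`: 7380 nM
- compound 2 `C#CCN(CCCCOc1ccc2ccc(=O)oc2c1)Cc1cccc(F)c1`: 1550 nM

In an assay on isolated protein for inhibition of Amine oxidase [flavin-containing] B (Homo sapiens), read by fluorescence and Amplex Red, with stated times of 15 min and 20 min (a higher number here means a weaker inhibitor, a lower number a stronger inhibitor), compound 1 stands with the higher of the two numbers; compound 2 gives 1550 nM, a gap beyond the usual scatter. Compound 3 `C#CCN(C)CCCOc1ccc2ccc(=O)oc2c1` differs from compound 1 by hydrogen in place of 4-methylphenyl on a saturated chain carbon bound to an amine nitrogen. Going by the values given here, no measured pair shows such a change, so only a direction can be expected: with the 4-methylphenyl gone, a step toward a higher number, of moderate size, is expected for compound 3, namely a 2.7-fold higher number from compound 1 to compound 3 (0.43 log units; beyond the scatter). Compound 3 is estimated at 20000 nM, within 5000 nM to 80000 nM.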

Compound 3, half-maximal inhibitory concentration: 1090 nM
Compound 3: middle estimate off by 18-fold (1.26 log units), on the high side, outside the stated range (below it).
By their numbers in this assay, from the lowest: compounds 3 and 2 (each within the scatter of the next); then compound 1.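

In this assay, going from 4-methylbenzyl to methyl gives a 6.8-fold lower number from compound 1 to compound 3 (0.83 log units; beyond the scatter). Activity at this position therefore does not depend on the 4-methylphenyl, and in compound 1 that group goes with the weaker inhibition. Nothing at hand explains the size of this step. Still open, from the compounds shown here alone, is how a plain benzyl, an ethyl or a cyclopropyl would read at this position, and whether the 4-methyl group itself contributes to the step. Also open, going by these compounds, is how a longer chain would read in compound 3.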